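This account rests on a few compounds, and the source may have more. Where it says the series, first, only, none or still open, it means among the compounds named here.

Three compounds share one core and are compared in a functional assay on SK-BR-3 cells (Homo sapiens) for antiproliferative activity, read by MTT assay, with a stated time of 72 h; a lower number here means a stronger inhibitor, a higher number a weaker inhibitor. Compound 1 `Cc1cc(NCCN2CCN(C)CC2)nc2ccc(NC(=O)c3ccc(Cl)c(Cl)c3)cc12` gives 2690 nM. Compound 2 `CCN1CCN(c2cc(C)c3cc(NC(=O)c4cc(Cl)cc(Cl)c4)ccc3n2)CC1` gives 2660 nM, the lowest number shown, although compound 1 sits within the scatter of it. Compound 3 `Cc1cc(NCCN2CCCC2)nc2ccc(NC(=O)c3ccc(Cl)c(Cl)c3)cc12` gives 9530 nM. Among the measured compounds shown here, the only step that joins two measured compounds runs a 3.5-fold higher number from compound 1 to compound 3 (0.55 log units; beyond the scatter), and it concerns the amine end of the molecule, not the amide end.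

Compound 4 `CCN1CCN(c2cc(C)c3cc(NC(=O)c4ccc(Br)cc4)ccc3n2)CC1` has not yet been measured. It differs from compound 2 in this way: 4-bromophenyl in place of 3,5-dichlorophenyl on a carbonyl carbon. For the measured compounds named here, no measured step covers a change on the ring attached to the carbonyl carbon, so the direction of the step in this assay cannot be read from the numbers at hand; with nothing to go on, a step within the scatter, or a modest weakening, is the plain expectation. Compound 4 is therefore estimated to give 4000 nM, ranging from 1500 nM to 12000 nM, which means an expected step of a 1.5-fold higher number from compound 2 to compound 4 (0.18 log units; within the scatter).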

Compound 4, half-maximal inhibitory concentration: 6310 nM
Beside the measured number, compound 4's estimate is 1.6-fold (0.20 log units) below it, within the range that was stated.
By their numbers in this assay, from the lowest: compounds 2 and 1 (each within the scatter of the next); then compounds 4 and 3 (each within the scatter of the next).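

Among the compounds shown here, until now, the only measured step lay at the amine end of the molecule, so this is the first reading of the ring on the carbonyl carbon. In this assay, putting 4-bromophenyl in place of 3,5-dichlorophenyl gives a 2.4-fold higher number from compound 2 to compound 4 (0.38 log units; beyond the scatter), which shows that activity responds to this ring, though the step is modest. No measurement shown bears on the reason for this step.

This single change alters both the halogen and the substitution pattern of the ring, so the compounds shown cannot separate the two. A 4-chlorophenyl or a 3,5-dibromophenyl group on the same carbonyl carbon would help to do so, and a ring carrying a carboxylic acid would test a very different kind of group there.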